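Pyridyl to Dichlorophenyl Ester on a Triterpenoid Core

A few compounds are considered here, and "the series" means these few. Any claim that something is new, unique, unknown or untested is made for them only; others in the source may bear on it.

The series rests on a shared core carrying an ester at one end. Compound 1 `CC1=CC[C@H]2[C@H](CC[C@]2(C)O)C(C)(C)[C@@H]1CC[C@H]1[C@]2(C)CC[C@H](OC(=O)c3ccncc3)C(C)(C)O[C@H]2CC[C@@]1(C)O` bears a pyridin-4-yl carbonyl there; in a functional assay on MDA-MB-231 cells (Homo sapiens) for antiproliferative activity, read by MTT assay, with a stated time of 72 h (a lower number here means a stronger inhibitor, a higher number a weaker inhibitor), compound 1 gives 18000 nM. Among the three measured numbers it holds the second highest place: its nearest neighbour is compound 3, and its most distant is compound 2, yet both of these gaps lie within the scatter, so no order among the three can be read. Compound 2 `CC1=CC[C@H]2[C@@H]1CC=C(C)[C@@H](CC[C@H]1[C@]3(C)CC[C@H](OC(=O)CCC(=O)O)C(C)(C)O[C@H]3CC[C@@]1(C)O)C2(C)C` carries a carboxyethyl carbonyl and gives 29600 nM in this assay. Compound 3 `CC1=CC[C@H]2[C@@H]1CC=C(C)[C@@H](CC[C@H]1[C@]3(C)CC[C@H](OC(=O)c4ccc(Cl)cc4)C(C)(C)O[C@H]3CC[C@@]1(C)O)C2(C)C` carries a 4-chlorophenyl carbonyl and gives 12700 nM in this assay.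

Compound 4 `CC1=CC[C@H]2[C@H](CC[C@]2(C)O)C(C)(C)[C@@H]1CC[C@H]1[C@]2(C)CC[C@H](OC(=O)c3ccc(Cl)c(Cl)c3)C(C)(C)O[C@H]2CC[C@@]1(C)O` is the unmeasured member. Its difference from compound 1 is 3,4-dichlorophenyl in place of pyridin-4-yl on a carbonyl carbon. Going by the values given here, the only measured step that bears on it is the exchange of a chain for a chlorinated aryl group on the same carbonyl carbon, a 2.3-fold lower number from compound 2 to compound 3 (0.37 log units; beyond the scatter). By analogy with that modest move, compound 4 is expected to give a somewhat lower number than compound 1, a 2.0-fold lower number from compound 1 to compound 4 (0.30 log units; within the scatter), though the step may not exceed the scatter. The estimate for compound 4 in this assay is 9000 nM, with a range from 4000 nM to 20000 nM.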

Compound 4, half-maximal inhibitory concentration: 8100 nM
The estimate for compound 4 lay 1.1-fold (0.05 log units) above the measured number; measured number inside the range.
By their numbers in this assay, from the lowest: compounds 4, 3, 1 and 2 (each within the scatter of the next, the first and the last beyond it).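

In this assay, the exchange of pyridin-4-yl for 3,4-dichlorophenyl on the carbonyl carbon gives a 2.2-fold lower number from compound 1 to compound 4 (0.35 log units; beyond the scatter). Going by these compounds alone, this shows that one aromatic ring in place of another at this position can move the number beyond the scatter, whereas the one earlier step replaced a chain with an aryl group and was read on a core that is not the core of compound 1. The change takes away a ring with one nitrogen and one hydrogen-bond acceptor and brings in a carbon-only ring with two chlorines, and no measurement given here accounts for the step.

Within the data shown here, the single step cannot separate the loss of the ring nitrogen from the gain of the chlorines, and a plain phenyl or a 4-chlorophenyl on the core of compound 1 would be needed to divide the two. Also open, going by these compounds, is how this position on the same core would respond to a ring bearing an amine or a methoxy group, or to a longer chain ending in a carboxylic acid.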